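Moving the formyl group on the aryl ether of compound 2

The source may hold more compounds than are shown below. What is called first, only, known or untested is meant among the compounds shown, and "the series" means these compounds.

Compound 2 `COc1cc2c(cc1OC)CN(S(=O)(=O)c1ccc(-n3cc(COc4cc(C=O)ccc4OC)nn3)cc1)CC2`: 5820 nM
Compound 1 `COc1cc2c(cc1OC)CN(S(=O)(=O)c1ccc(-n3cc(COc4ccc(C=O)cc4)nn3)cc1)CC2`: 34100 nM

In a functional assay on MOLT-3 cells (Homo sapiens) for cytotoxicity, read by MTT assay, with a stated time of 48 h (a lower number here means a stronger inhibitor, a higher number a weaker inhibitor), compound 2 stands at the lowest of the two numbers shown, and compound 1 sits higher. Compound 3 `COc1cc2c(cc1OC)CN(S(=O)(=O)c1ccc(-n3cc(COc4ccc(C=O)cc4OC)nn3)cc1)CC2` keeps every atom of compound 2 but joins them differently: 4-formyl-2-methoxyphenyl in place of 5-formyl-2-methoxyphenyl on an oxygen on a saturated carbon. Going by the values given here, the only step that bears on this, a 5.9-fold lower number from compound 1 to compound 2 (0.77 log units; beyond the scatter), also shifted the formyl and methoxy groups on this same aryl ether, and it was modest. A step of similar size in either direction is therefore plausible, with no secure direction. Compound 3 is estimated at 8000 nM, with a range from 2500 nM to 25000 nM. That would be an expected 1.4-fold higher number from compound 2 to compound 3 (0.14 log units; within the scatter).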

Compound 3, half-maximal inhibitory concentration: 5500 nM
The estimate for compound 3 lay 1.5-fold (0.16 log units) above the measured number; low and high end bracket the measured number.
By their numbers in this assay, from the lowest: compounds 3 and 2 (each within the scatter of the next); then compound 1.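

In this assay, 4-formyl-2-methoxyphenyl in place of 5-formyl-2-methoxyphenyl gives a 1.1-fold lower number from compound 2 to compound 3 (0.02 log units; within the scatter) and so leaves the number unchanged within the scatter. Adding only a methoxy in place of hydrogen on an aromatic carbon gives a 6.2-fold lower number from compound 1 to compound 3 (0.79 log units; beyond the scatter) and shows that, among these three compounds, the drop goes with the methoxy rather than with where the formyl group sits. As far as these compounds go, what a carboxylic acid or an amine would do in place of the formyl group stays open, as does an ethoxy in place of the methoxy. Nothing available here explains these results.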